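Working notes: removing the chloro substituent from compound 1

The source may hold more compounds than are shown below. What is called first, only, known or untested is meant among the compounds shown, and "the series" means these compounds.

Measured compounds:
compound 1 `COc1ccc2c(=O)c(/C=C/C(=O)Nc3cccc(Cl)c3)coc2c1` — > 200000 nM, a limit of the assay
compound 2 `O=C(/C=C/c1coc2cc(O)ccc2c1=O)NCc1ccccc1` — > 200000 nM, a limit of the assay

Both compounds were tested in a functional assay on L02 cells (Homo sapiens) for inhibition, read by MTT assay, with a stated time of 48 h; a higher number here means a weaker inhibitor, a lower number a stronger inhibitor. Compound 1 gives only a limit there, > 200000 nM, and no number. Compound 2 likewise reaches only a limit, > 200000 nM. So compound 1 stands nowhere on a scale of numbers; it sits at the same boundary as the one other compound shown, and the two values show no difference between them. Among the measured compounds shown here, the single piece of evidence available is the limit of > 200000 nM in this assay, at which 2 of the 2 values shown sit.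

Compound 3 `COc1ccc2c(=O)c(/C=C/C(=O)Nc3ccccc3)coc2c1` has not yet been measured in this assay. It differs from compound 1 by hydrogen in place of chloro on an aromatic carbon. For the measured compounds named here, no measured pair of compounds carries this change, so no step size can be read off. Given that compound 1 is itself a limit, > 200000 nM, the expectation is no step beyond the scatter in either direction, and most probably a further limit rather than a number. Compound 3 is estimated at 300000 nM, within 100000 nM to 1000000 nM, which means an expected step that the limit leaves unreadable from compound 1 to compound 3.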

Compound 3, half-maximal inhibitory concentration: > 200000 nM
Compound 3 was reported as a limit; the forecaster's own chance of this, stated with the estimate: 85%; the middle value is on the limit's open side.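

Compound 1 and compound 3 both sit at a limit in this assay and not at a number, so no step can be read for hydrogen in place of chloro on an aromatic carbon. The compounds shown leave open whether any compound of this series gives a number in this assay at all: the limit of > 200000 nM in this assay, at which 3 of the 3 values shown sit.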